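The source may report more compounds than this note shows. Statements on the series, on what has been measured and on what is new or still open speak of the compounds shown alone.

Measured so far:
compound 1 `CO/N=c1/ccn([C@]23C[C@H]2[C@H](COP(=O)(O)OP(=O)(O)OP(=O)(O)OC[C@@H]2[C@@H](O)[C@@H](O)[C@@]4(n5ccc(=O)[nH]c5=O)C[C@@H]24)[C@@H](O)[C@H]3O)c(=O)[nH]1`: 6900 nM
compound 2 `O=c1[nH]/c(=N\OCc2ccccc2)ccn1[C@]12C[C@H]1[C@H](COP(=O)(O)OP(=O)(O)O)[C@@H](O)[C@H]2O`: 793 nM

Both were tested in a functional assay on cells for agonist activity at P2Y purinoceptor 6 (Homo sapiens), read by FLIPR and calcium flux; on this read-out higher numbers stand for an effect only at larger amounts of compound and lower numbers for an effect already at smaller amounts. Compound 1 gives 6900 nM in this assay, the highest of the two numbers; compound 2, with 793 nM, lies well beyond the usual scatter from it. The two structures differ in many places at once, so their gap cannot be tied to any single change. Compound 3 `CO/N=c1/ccn([C@]23C[C@H]2[C@H](COP(=O)(O)OP(=O)(O)OP(=O)(O)OC[C@@H]2[C@@H](O)[C@@H](O)[C@@]4(n5cc/c(=N/OC)[nH]c5=O)C[C@@H]24)[C@@H](O)[C@H]3O)c(=O)[nH]1` is not yet measured. It differs from compound 1 in one place: a group of 10 heavy atoms (5 carbon, 3 nitrogen, 2 oxygen; one six-membered aromatic ring with 2 hetero atoms) in place of a group of 8 heavy atoms (4 carbon, 2 nitrogen, 2 oxygen; one six-membered aromatic ring with 2 hetero atoms), on a saturated ring carbon. Within the data shown here, no measured pair of compounds shows this exact change, so there is no step to lean on. The step from compound 1 to compound 3 is expected to be modest, toward a lower number, and is estimated as a 1.7-fold lower number from compound 1 to compound 3 (0.24 log units; within the scatter). For compound 3 a value of about 4000 nM is expected, within a range from 1200 nM to 14000 nM.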

Compound 3, half-maximal effective concentration: 5490 nM
Beside the measured number, compound 3's estimate is 1.4-fold (0.14 log units) below it; measured number inside the range.
By their numbers in this assay, from the lowest: compound 2; then compounds 3 and 1 (each within the scatter of the next).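

In this assay, the group of 10 heavy atoms in place of the group of 8 heavy atoms, on a saturated ring carbon of a three-membered non-aromatic ring of carbon only, gives a 1.3-fold lower number from compound 1 to compound 3 (0.10 log units; within the scatter) and so stays within the scatter. Among these compounds, this is the first comparison here in which only one place differs, and it shows that this position accepts the larger of these two groups with no measurable shift in the read-out. No measurement shown offers an explanation for this result. The compounds shown leave open whether a ring carrying an amine or a carboxylic acid at this same position would also leave the number unmoved. They also leave open whether a longer chain, such as butyl, on this ring would do the same.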